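Aryl ether in place of fluorophenyl on the quinoline core

The source may hold more compounds than are shown below. What is called first, only, known or untested is meant among the compounds shown, and "the series" means these compounds.

Compound 1 `COc1ccc(-c2ccc3c(NCCCNCc4cccc(OC)c4O)ccnc3c2)cc1` gives 1600 nM in an ADME assay on HepG2 cells (Homo sapiens) for cytotoxicity, read by luminescence, CellTiter-Glo and ATP content, with a stated time of 72 h; a lower number here means that less compound is needed, a higher number that more compound is needed for the effect. Compound 2 `Fc1ccc(-c2ccc3c(NCCCNCc4ccco4)ccnc3c2)cc1` gives 7760 nM. Compound 3 `COc1cccc(CNCCCNc2ccnc3cc(-c4ccc(F)cc4)ccc23)c1O` gives 6840 nM.

Among these three, compound 2 has the highest number, but its neighbour compound 3 lies within the scatter, since a 1.1-fold lower number from compound 2 to compound 3 (0.05 log units; within the scatter); only compound 1 sits clearly apart from it. Compound 4 `COc1cccc(Oc2ccc3c(NCCCNCc4ccco4)ccnc3c2)c1` is not yet measured. It differs from compound 2 in one place: 3-methoxyphenoxy in place of 4-fluorophenyl on an aromatic carbon.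

Among the measured compounds shown here, one measured step touches the same position: a 4.3-fold higher number from compound 1 to compound 3 (0.63 log units; beyond the scatter), a modest change beyond the scatter. Read in reverse it suggests that putting an oxygen-bearing group back on this ring could lower the number, though the new group is an ether and the methoxy sits differently, so the comparison is loose. The step of a 1.1-fold lower number from compound 2 to compound 3 (0.05 log units; within the scatter) concerns another part of the molecule and adds little.

Compound 4 is therefore expected to show a modestly lower number, a 1.9-fold lower number from compound 2 to compound 4 (0.29 log units; within the scatter), with an estimate of 4000 nM and a range from 1500 nM to 12000 nM.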

Compound 4, half-maximal effective concentration: 15500 nM
For compound 4 the middle estimate is 3.9-fold (0.59 log units) below the measured one; the whole stated range lies below it.
By their numbers in this assay, from the lowest: compound 1; then compounds 3, 2 and 4 (each within the scatter of the next, the first and the last beyond it).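

In this assay, replacing the whole 4-fluorophenyl group with 3-methoxyphenoxy on this aromatic carbon gives a 2.0-fold higher number from compound 2 to compound 4 (0.30 log units; within the scatter), so this larger change, which brings in an oxygen-linked ring, leaves the number within the scatter of compound 2. Among the compounds shown here, the only earlier step at this position, a 4.3-fold higher number from compound 1 to compound 3 (0.63 log units; beyond the scatter), lay beyond the scatter, but it exchanged only fluoro and methoxy on the ring, and its size does not carry over to the new replacement. No measurement available here accounts for the result.

The compounds shown do not separate any contribution of the linking oxygen from that of the methoxy group, which a plain phenoxy or a benzyloxy group at this place could help to do. They also leave open how 3-methoxyphenoxy would read alongside the 2-hydroxy-3-methoxyphenyl side chain instead of furan-2-yl.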